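Swapping methyl for bromo in a weak growth inhibitor

The compounds below may be only part of what the source reports. "The series", "measured", "known", "first", "only" and "open" are said of these compounds alone.

compound 1 `Cc1ccc(NC(=S)N/N=C2\C(=O)Nc3ccc([N+](=O)[O-])cc32)cc1`: 30%
compound 2 `O=C1Nc2ccc([N+](=O)[O-])cc2/C1=N/NC(=S)Nc1ccccc1C(F)(F)F`: 25%

In a functional assay on the whole organism for inhibition, with Lemna aequinoctialis as the target, tested at 1000 ug/mL (a higher number here means more inhibition of growth at the concentration tested, a lower number less inhibition of growth), compound 1 gives 30%, the higher of the two numbers shown, yet compound 2 gives 25%, and the gap between them lies within the scatter, so the two cannot be told apart. Compound 3 `O=C1Nc2ccc([N+](=O)[O-])cc2/C1=N/NC(=S)Nc1ccc(Br)cc1` differs from compound 1 in one place: bromo in place of methyl on an aromatic carbon. Among the measured compounds shown here, no measured pair shows this change, so no step can be read from the data, and no shift beyond the scatter is expected in either direction. Compound 3 is therefore estimated at 28%, within 10% to 50%, which means an expected step of a number 2 percentage points lower from compound 1 to compound 3 (within the scatter).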

Compound 3, percent growth inhibition at one concentration: 20%
The estimate for compound 3 lay 8 percentage points above the measured number; the measured number falls inside the stated range.
By their numbers in this assay, from the lowest: compounds 3, 2 and 1 (each within the scatter of the next).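

Bromo in place of methyl gives the only pair here that differs in one place, and in this assay the change from 4-methylphenyl to 4-bromophenyl is a number 10 percentage points lower from compound 1 to compound 3 (within the scatter). At this position, then, the swap leaves no difference that can be told from the scatter. No evidence on any property of either group bears on this result. As far as these compounds go, whether an amine, a carboxylic acid or a methoxy group at this position would shift the number beyond the scatter remains open, as does the effect of bromo on another ring carbon.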